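The compounds below may be only part of what the source reports. "The series", "measured", "known", "first", "only" and "open" are said of these compounds alone.

Compound 3 `CN(C)c1c(C#N)c2c(N)ncnc2n1C` is the weakest of the three compounds measured in an assay on isolated protein for inhibition of Leucine-rich repeat serine/threonine-protein kinase 2 variant G2019S (Homo sapiens), read by TR-FRET and LanthaScreen, with stated times of 50 min and 30 min, in the presence of a further agent that is not named here (a higher number here means a weaker inhibitor, a lower number a stronger inhibitor), where compound 3 gives 3760 nM. Among the measured compounds shown here, compound 1 `Cc1c(Nc2nc(N)c3c(C#N)c(N4CCC[C@H]4C)n(C)c3n2)cnn1C` gives 43 nM and compound 2 `C[C@@H]1CCCN1c1c(C#N)c2c(N)nc(Nc3cn[nH]c3)nc2n1C` gives 6 nM in this assay; both carry a 2-methylpyrrolidin-1-yl group together with a pyrazole attached through a nitrogen, and the single step between them, a 7.2-fold lower number from compound 1 to compound 2 (0.86 log units; beyond the scatter), concerns only that pyrazole. Compound 4 `C[C@@H]1CCCN1c1c(C#N)c2c(N)ncnc2n1C` alters a different place: 2-methylpyrrolidin-1-yl in place of dimethylamino on an aromatic carbon. For the measured compounds named here, no measured step isolates this change, and compound 3 lacks the pyrazole shared by compounds 1 and 2, so their wide gap cannot be attributed to the pyrrolidine alone. A modest gain is expected: a 3.1-fold lower number from compound 3 to compound 4 (0.50 log units; beyond the scatter). Compound 4 is therefore estimated at 1200 nM, with a range from 300 nM to 4000 nM.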

Compound 4, half-maximal inhibitory concentration: 11 nM
Estimate against measurement, compound 4: 110-fold (2.04 log units) above; measured number outside the range, below it.
By their numbers in this assay, from the lowest: compounds 2 and 4 (each within the scatter of the next); then compound 1; then compound 3.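

On this aromatic carbon, 2-methylpyrrolidin-1-yl in place of dimethylamino gives a 340-fold lower number from compound 3 to compound 4 (2.53 log units; beyond the scatter) with no pyrazole present, so this one change can by itself yield a strong inhibitor. Hydrogen in place of the pyrazole-bearing amine gives a 1.8-fold higher number from compound 2 to compound 4 (0.26 log units; within the scatter) for the unmethylated pyrazole and a 3.9-fold lower number from compound 1 to compound 4 (0.59 log units; beyond the scatter) for the dimethylated one, so neither group is needed for strong inhibition here. Nothing available explains the size of the pyrrolidine gain.
On these data alone, whether the gain comes from the ring or from its methyl stays open: plain pyrrolidin-1-yl at this carbon would separate the two.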